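The source may report more compounds than this note shows. Statements on the series, on what has been measured and on what is new or still open speak of the compounds shown alone.

Measured compounds:
compound 1 `CC(C)c1cccc(C(C)C)c1NC(=O)NCC1(c2ccc(C(C)(C)C)cc2)CCCC1` — 63 nM
compound 2 `CC(C)c1cccc(C(C)C)c1NC(=O)NCC1(c2ccc(OCc3ccccc3)cc2)CCCC1` — 34 nM
compound 3 `CC(C)c1cccc(C(C)C)c1NC(=O)NCC1(c2ccc(C(F)(F)F)cc2)CCCC1` — 66 nM

In an assay on microsomes for inhibition of acyl-CoA:cholesterol acyltransferase (Oryctolagus cuniculus) (on this read-out lower numbers stand for stronger inhibition and higher numbers for weaker inhibition), compound 3 gives the highest of the three numbers, yet a 1.0-fold higher number from compound 1 to compound 3 (0.02 log units; within the scatter) and a 1.9-fold higher number from compound 2 to compound 3 (0.29 log units; within the scatter) are both within the scatter, so the three compounds cannot be told apart. Compound 4 `CC(C)c1cccc(C(C)C)c1NC(=O)NCC1(c2cccc(CO)c2)CCCC1` differs from compound 3 by 3-(hydroxymethyl)phenyl in place of 4-(trifluoromethyl)phenyl on a saturated ring carbon. Going by the values given here, none of the measured steps bears directly on this change: each of them only exchanges one group for another on the same aromatic carbon, and all three stayed within the scatter. With no guide to an exchange of this kind, the expected step in this assay is a 1.4-fold higher number from compound 3 to compound 4 (0.13 log units; within the scatter), a change not beyond the scatter. For compound 4 the estimate is 90 nM, within a range from 30 nM to 270 nM.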

Compound 4, half-maximal inhibitory concentration: 15 nM
Compound 4: the middle estimate sits 6.0-fold (0.78 log units) above what was measured; measured number below the stated range.
By their numbers in this assay, from the lowest: compound 4; then compounds 2, 1 and 3 (each within the scatter of the next).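

Replacing the whole aryl group on the saturated ring carbon moves the number beyond the scatter in this assay, which no exchange on the aromatic carbon had done: a 4.4-fold lower number from compound 3 to compound 4 (0.64 log units; beyond the scatter), and a 4.2-fold lower number from compound 1 to compound 4 (0.62 log units; beyond the scatter). The step therefore holds from two starting points, with 3-(hydroxymethyl)phenyl replacing either 4-(trifluoromethyl)phenyl or 4-(tert-butyl)phenyl. Nothing available explains this gain.

In both steps the group and its place on the phenyl ring change together, so the compounds shown leave open which of the two carries the step. On these data alone, how an amine or a carboxylic acid in place of the hydroxyl would behave also stays open.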